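Fluoro to Chloro on Compound 1

The compounds below may be only part of what the source reports. "The series", "measured", "known", "first", "only" and "open" are said of these compounds alone.

In a functional assay on PC-3 cells (Homo sapiens) for cytotoxicity, read by MTT assay, with a stated time of 24 h (on this read-out higher numbers stand for weaker inhibition and lower numbers for stronger inhibition), compound 1 (`COc1ccc(/C=C2\CN(C(=S)SCc3cn(Cc4ccccc4F)nn3)C/C(=C\c3ccc(OC)cc3)C2=O)cc1`) gives 31500 nM, the higher of the two exact numbers. Compound 2 (`O=C1/C(=C/c2ccccc2F)CN(Cc2cn(Cc3cccc(Cl)c3)nn2)C/C1=C\c1ccccc1F`) gives 6800 nM, lower by more than the scatter. Compound 3 (`O=C1/C(=C/c2ccccc2F)CN(C(=S)SCc2cn(Cc3ccccc3Cl)nn2)C/C1=C\c1ccccc1F`), which carries 2-chlorobenzyl, is recorded only as a limit, > 80000 nM. Compound 4 (`COc1ccc(/C=C2\CN(C(=S)SCc3cn(Cc4ccccc4Cl)nn3)C/C(=C\c3ccc(OC)cc3)C2=O)cc1`) differs from compound 1 by chloro in place of fluoro on an aromatic carbon, ortho to a large group, so that 2-fluorobenzyl becomes 2-chlorobenzyl: chloro in place of fluoro on an aromatic carbon. Going by the values given here, no measured pair shows this exchange alone, so no change beyond the scatter is expected in this assay. The expected step is a 1.1-fold higher number from compound 1 to compound 4 (0.06 log units; within the scatter). Compound 4 is estimated at 36000 nM, with an expected range of 15000 nM to 80000 nM.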

Compound 4, half-maximal inhibitory concentration: 60100 nM
Compound 4: middle estimate off by 1.7-fold (0.22 log units), on the low side; measured number inside the range.
By their numbers in this assay, from the lowest: compound 2; then compounds 1 and 4 (each within the scatter of the next). At a limit, above all of these: compound 3.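

Going by these compounds alone, on the benzyl group of compound 1, this is the first direct reading of chloro in place of fluoro on an aromatic carbon: in this assay there is a 1.9-fold higher number from compound 1 to compound 4 (0.28 log units; within the scatter). The earlier compounds shown here differ from one another in more than one place, so they could not isolate this exchange, which here stays within the usual scatter. Nothing measured here gives a cause for this step.

The compounds shown leave open how bromo, methyl or plain hydrogen on this same carbon would read, and whether the exchange reads alike on the core of compound 2.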